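Amide nitrogen substituents on a shared dimethoxy core

A few compounds are considered here, and "the series" means these few. Any claim that something is new, unique, unknown or untested is made for them only; others in the source may bear on it.

Measured compounds:
compound 1 `CCNC(=O)CC1CCc2cc(OC)c(OC)cc21` gives 33.3%
compound 2 `COc1cc2c(cc1OC)C(CC(=O)NC(C)C)CC2` gives 30%

In a functional assay on the whole organism (strain Wistar) for inhibition, with Rattus norvegicus as the target, read by paw edema, with stated times of 60 min and 24 h, at a dose of 100 mg/kg by the oral route (a lower number here means less inhibition, a higher number more inhibition at the dose given (going by the name of the read-out)), compound 1 gives 33.3%. In the same run compound 2 gives 30%. For the measured compounds named here, compound 2 sits within the scatter of compound 1: the step of a number 3.3 percentage points lower from compound 1 to compound 2 (within the scatter) is the only measured step, and it does not reach beyond the scatter of repeated measurements.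

Compound 3 `CCCCCNC(=O)CC1CCc2cc(OC)c(OC)cc21` is the next member to be tested. It differs from compound 2 by pentyl in place of isopropyl on an amide-type nitrogen. Going by the values given here, the one step that bears on this change is a number 3.3 percentage points lower from compound 1 to compound 2 (within the scatter), since it also alters the group on the amide-type nitrogen and stayed within the scatter. Among the compounds with values here, no measured step shows a chain of this length on the amide-type nitrogen, so no direction can be drawn from the data. The step expected is therefore no change at the digits printed from compound 2 to compound 3 (within the scatter), none beyond the scatter. Compound 3 is estimated at 30%, with a range from 15% to 45%.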

Compound 3, a percentage reported as inhibition, in the whole organism at one dose (the size of the read-out at that dose, not a potency): 46.7%
For compound 3 the middle estimate is 16.7 percentage points below the measured one; the whole stated range lies below it.
By their numbers in this assay, from the lowest: compounds 2 and 1 (each within the scatter of the next); then compound 3.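

In this assay, the amide-type nitrogen now shows a step that clears the scatter: pentyl in place of isopropyl gives a number 16.7 percentage points higher from compound 2 to compound 3 (beyond the scatter) and the comparison with the other short-chain amide gives a number 13.4 percentage points higher from compound 1 to compound 3 (beyond the scatter), so both point the same way. The groups on this nitrogen in compound 1 and compound 2 stood within the scatter of each other, whereas the pentyl group of compound 3 stands clear of both. No measurement on hand bears on the reason for this step.

Three compounds cannot tell whether the number keeps climbing as the chain on this nitrogen grows or already levels off at pentyl, and an octyl chain would test that. As far as these compounds go, whether the chain must be plain carbon also stays open, as a pentyl chain ending in a carboxylic acid or an amine would show.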